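A few compounds are considered here, and "the series" means these few. Any claim that something is new, unique, unknown or untested is made for them only; others in the source may bear on it.

Measured so far:
Compound 1 `COc1ccc(C2=NN(c3ccc(S(C)(=O)=O)cc3)C(=O)CC2)cc1` gives 46.7% in a functional assay on the whole organism (strain Wistar) for inhibition, with Rattus norvegicus as the target, read by paw edema, with stated times of 30 min and 3 h, at a dose of 0.05 mmol/kg by the oral route; a higher number here means more inhibition at the dose given (going by the name of the read-out), a lower number less inhibition.
Compound 2 `CS(=O)(=O)c1ccc(N2N=C(c3ccc(Cl)cc3)CCC2=O)cc1` gives 26.6% in this assay.

Both compounds share the same core and differ only in the group on the outer aromatic ring. Compound 2 stands lowest of the two numbers; its nearest neighbour is compound 1, whose value sits beyond the scatter above it, as the step of a number 20.1 percentage points lower from compound 1 to compound 2 (beyond the scatter) shows.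

Compound 3 `CC(C)(C)c1ccc(C2=NN(c3ccc(S(C)(=O)=O)cc3)C(=O)CC2)cc1` carries a tert-butyl group where compound 2 carries chloro: tert-butyl in place of chloro on an aromatic carbon. Among the measured compounds shown here, the only measured step, a number 20.1 percentage points lower from compound 1 to compound 2 (beyond the scatter), concerns a different exchange, methoxy against chloro, so no measured step speaks directly to tert-butyl in place of chloro. The two numbers in hand show that changing this one group can move the read-out by a modest amount, but they give no guide to the direction for this new group. The step of a number 3.4 percentage points higher from compound 2 to compound 3 (within the scatter) is therefore expected to be small and of uncertain direction. Compound 3 is estimated at 30%, within the range 10% to 50%.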

Compound 3, a percentage reported as inhibition, in the whole organism at one dose (the size of the read-out at that dose, not a potency): 50%
Compound 3: the middle estimate sits 20 percentage points below what was measured, within the range that was stated.
By their numbers in this assay, from the lowest: compound 2; then compounds 1 and 3 (each within the scatter of the next).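

In this assay, tert-butyl in place of chloro gives a number 23.4 percentage points higher from compound 2 to compound 3 (beyond the scatter), so the low number of compound 2 now stands apart from two different groups at this place rather than from methoxy alone. Tert-butyl in place of methoxy gives a number 3.3 percentage points higher from compound 1 to compound 3 (within the scatter), so this assay does not separate these two groups, even though tert-butyl is all carbon and methoxy is not; with only these three compounds, chloro is the one group that stands apart. Nothing measured here explains why the chloro compound differs from the other two.

On these data alone, whether the low number belongs to chloro alone remains open: fluoro or bromo at the same place would test that, while an amine or a carboxylic acid would show whether a very different kind of group stays level with compound 1 and compound 3. As far as these compounds go, each number also comes from a single oral dose, so how far these differences would hold at other doses remains open as well.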